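Swapping Methylsulfanyl for Methylamino on Compound 1

A few compounds are considered here, and "the series" means these few. Any claim that something is new, unique, unknown or untested is made for them only; others in the source may bear on it.

Measured so far:
compound 1 `CSc1[nH]ccc2ncnc1-2`: 4%
compound 2 `[O-][n+]1ccc2[nH]cnc2c1`: 3%

In a functional assay (Homo sapiens) for inhibition of Nucleic Acid, tested at 100 uM (a lower number here means less inhibition, a higher number more inhibition at the concentration tested (going by the name of the read-out)), compound 1 gives 4%, the top of these two numbers, yet compound 2 lies within the usual scatter of it, so the two cannot be told apart, and both show almost no inhibition. Compound 3 `CNc1[nH]ccc2ncnc1-2` differs from compound 1 in one place: methylamino in place of methylsulfanyl on an aromatic carbon. Within the data shown here, no step between measured compounds is available to guide the outcome. The step of a number 1 percentage points higher from compound 1 to compound 3 (within the scatter) is expected to stay within the scatter, in no clear direction. Compound 3 is estimated at 5%, with a range from -5% to 15%.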

Compound 3, a percentage reported as inhibition, at one concentration (the size of the read-out at that concentration, not a potency): 18%
The estimate for compound 3 lay 13 percentage points below the measured number, outside the stated range (above it).
By their numbers in this assay, from the lowest: compounds 2 and 1 (each within the scatter of the next); then compound 3.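

In this assay, among these compounds, methylamino in place of methylsulfanyl gives a number 14 percentage points higher from compound 1 to compound 3 (beyond the scatter), so the group on this aromatic carbon, next to the ring nitrogen, can change the read-out, something the earlier compounds could not show. The incoming group brings a hydrogen-bond donor that the outgoing one lacks, but nothing available explains the step. From the compounds shown here alone, whether the donor matters remains open, and dimethylamino, which has no such hydrogen, would test this. Ethylamino, a longer chain, would show whether the number with a larger group on the nitrogen is higher, lower or level.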